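A few compounds are considered here, and "the series" means these few. Any claim that something is new, unique, unknown or untested is made for them only; others in the source may bear on it.

Of the compounds shown here, three built on the same core have been tested in a functional assay on the whole organism (strain Wistar) for inhibition, with Rattus norvegicus as the target, read by paw edema, with stated times of 60 min and 1 h, at a dose of 100 mg/kg by the oral route; a higher number here means more inhibition at the dose given (going by the name of the read-out), a lower number less inhibition. Compound 1 `COc1cc2c(cc1OC)C(CC(=O)N(C)C)CC2` gives 25%, compound 2 `CCN(CC)C(=O)CC1CCc2cc(OC)c(OC)cc21` gives 31.3%, and compound 3 `COc1cc2c(cc1OC)C(CC(=O)NCc1ccccc1)CC2` gives 18.8%. Compound 3 stands lowest of the three, although its gap to compound 1 is within the scatter; only the gap to compound 2 is beyond it.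

The step to compound 4 `COc1cc2c(cc1OC)C(CC(=O)N1CCCCC1)CC2` changes the amide nitrogen: piperidin-1-yl in place of benzylamino on a carbonyl carbon. Among the compounds with values here, two measured steps bear on this. Going the other way, from a tertiary amide to the benzylamino compound, cost a number 12.5 percentage points lower from compound 2 to compound 3 (beyond the scatter) and a number 6.2 percentage points lower from compound 1 to compound 3 (within the scatter). A piperidin-1-yl group, like dimethylamino and diethylamino, leaves the amide nitrogen without a hydrogen, so the change from compound 3 to compound 4 is expected to recover roughly what those steps lost, an estimated a number 9.2 percentage points higher from compound 3 to compound 4 (within the scatter). Compound 4 is therefore expected to give about 28% in this assay, likely between 15% and 40%.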

Compound 4, a percentage reported as inhibition, in the whole organism at one dose (the size of the read-out at that dose, not a potency): 18.8%
For compound 4 the middle estimate is 9.2 percentage points above the measured one; the range from low to high includes it.
By their numbers in this assay, from the lowest: compounds 3, 4, 1 and 2 (each within the scatter of the next, the first and the last beyond it).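

In this assay, the move to piperidin-1-yl gives no change at the digits printed from compound 3 to compound 4 (within the scatter) even though the amide hydrogen and the aromatic ring of benzylamino both leave, so neither the loss of that hydrogen nor the loss of that ring separates these two compounds. Lacking the amide hydrogen therefore does not by itself place a compound with compound 2, for the data show a number 12.5 percentage points lower from compound 2 to compound 4 (beyond the scatter) while also showing a number 6.2 percentage points lower from compound 1 to compound 4 (within the scatter) in a step that cannot be told from scatter. No available evidence explains the gap between the diethylamino and piperidin-1-yl amides.

The compounds shown leave open how a pyrrolidin-1-yl or morpholin-4-yl group on the carbonyl carbon would compare. They also leave open what a carboxylic acid in place of the amide would give.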